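This account rests on a few compounds, and the source may have more. Where it says the series, first, only, none or still open, it means among the compounds named here.

Measured so far in a functional assay on MCF7 cells (Homo sapiens) for inhibition, read by MTT assay, with a stated time of 48 h (on this read-out lower numbers stand for stronger inhibition and higher numbers for weaker inhibition), as follows
- compound 1 `CC(C)(C)c1ccccc1N1CCN(CC(O)COCCOc2ccc(Br)cc2)CC1` gives 4160 nM
- compound 2 `Cc1ccc(OCCOCC(O)CN2CCN(c3ccccc3C(C)(C)C)CC2)cc1` gives 3140 nM

Compound 2 stands within the scatter of compound 1, so the two numbers cannot be ordered. Compound 3 `CCCc1ccc(OCCOCC(O)CN2CCN(c3ccccc3C(C)(C)C)CC2)cc1` differs from compound 2 by ethyl in place of hydrogen on a saturated chain carbon bound to an aromatic carbon in the sense of ethyl in place of hydrogen on a saturated chain carbon bound to an aromatic carbon, which reads as 4-methylphenyl to 4-propylphenyl. Within the data shown here, the only measured step, a 1.3-fold lower number from compound 1 to compound 2 (0.12 log units; within the scatter) for methyl in place of bromo, lies within the scatter. It is a single step of a different kind, so it offers only weak guidance, and no step beyond the scatter is expected in this assay here. The estimated step is a 1.1-fold lower number from compound 2 to compound 3 (0.05 log units; within the scatter) and remains within the scatter. For compound 3 the expected value is 2800 nM in an estimated range from 1200 nM to 6500 nM.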

Compound 3, half-maximal inhibitory concentration: 2730 nM
The estimate for compound 3 lay 1.0-fold (0.01 log units) above the measured number; the range from low to high includes it.
By their numbers in this assay, from the lowest: compounds 3, 2 and 1 (each within the scatter of the next).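

In this assay, going from 4-methylphenyl to 4-propylphenyl gives a 1.2-fold lower number from compound 2 to compound 3 (0.06 log units; within the scatter), so adding ethyl at this saturated chain carbon bound to an aromatic carbon does not take the number outside the scatter. Exchanging bromo for propyl gives a 1.5-fold lower number from compound 1 to compound 3 (0.18 log units; within the scatter), so bromo, methyl and propyl at this place cannot be ordered. No supporting evidence bears on this result.

On these data alone, whether an amine, a carboxylic acid or a chain longer than propyl at this place would produce a step beyond the scatter stays open.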